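Removing Both Methyls from the Sulfonyl Aryl Group

The source may report more compounds than this note shows. Statements on the series, on what has been measured and on what is new or still open speak of the compounds shown alone.

Three compounds share one core and differ in the ring attached to the sulfonyl sulfur or in one substituent on the core. Compound 3 `Cc1ccc2ncc(S(=O)(=O)c3ccc(C)c(C)c3)c(N3CCC(C)CC3)c2c1` stands highest of the three in an assay on isolated protein for displacement of a labelled ligand from metabotropic glutamate receptor 5 (Homo sapiens), with a stated time of 60 min, tested at 1 uM (a higher number here means more inhibition at the concentration tested (going by the name of the read-out), a lower number less inhibition), giving 90%. Compound 1 `Cc1ccc(S(=O)(=O)c2cnc3ccc(Cl)cc3c2N2CCC(C)CC2)cc1C` gives 84% in this assay; the step of a number 6 percentage points higher from compound 1 to compound 3 (within the scatter) lies within the scatter. For the measured compounds named here, compound 2 `Cc1ccc2ncc(S(=O)(=O)c3cc(Cl)cc(Cl)c3)c(N3CCC(C)CC3)c2c1` gives 75%, and the step of a number 15 percentage points higher from compound 2 to compound 3 (beyond the scatter) is the only one that touches the ring on the sulfonyl sulfur.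

Compound 4 `Cc1ccc2ncc(S(=O)(=O)c3ccccc3)c(N3CCC(C)CC3)c2c1` has not been measured. It differs from compound 3 by phenyl in place of 3,4-dimethylphenyl on a sulfonyl sulfur. The step from compound 2 to compound 3 shows that changing this ring can move the read-out by a modest amount, but it swaps one substituted ring for another, so it only partly bears on losing both methyls. A modest drop is therefore expected, a number 12 percentage points lower from compound 3 to compound 4 (beyond the scatter), with compound 4 estimated at 78%, within a range from 60% to 92%.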

Compound 4, a percentage reported as inhibition, at one concentration (the size of the read-out at that concentration, not a potency): 67%
For compound 4 the middle estimate is 11 percentage points above the measured one, and the stated range covers the measured number.
By their numbers in this assay, from the lowest: compounds 4, 2, 1 and 3 (each within the scatter of the next, the first and the last beyond it).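

In this assay, removing both methyls and leaving an unsubstituted phenyl on the sulfonyl sulfur gives a number 23 percentage points lower from compound 3 to compound 4 (beyond the scatter), so the 3,4-dimethylphenyl ring does more here than simply fill the position. The plain ring and the 3,5-dichlorophenyl ring are not separated by this read-out, with a number 8 percentage points lower from compound 2 to compound 4 (within the scatter), which means that among these three rings only 3,4-dimethylphenyl stands apart from the other two. No measurement shown here accounts for this difference.

The compounds shown leave open whether one methyl is enough, a question that 3-methylphenyl and 4-methylphenyl rings on the sulfonyl sulfur would address. They also leave open whether the kind of group or its placement matters more, which a 3,4-dichlorophenyl ring could help separate.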